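The source may hold more compounds than are shown below. What is called first, only, known or untested is meant among the compounds shown, and "the series" means these compounds.

Measured so far in a functional assay for inhibition, with Homo sapiens as the target; a lower number here means tighter binding, a higher number weaker binding:

Compound 1 `O=C(O)CC/C=C\CC1COC(c2ccsc2)OC1c1cccnc1` — 1580 nM
Compound 2 `CC(C)(Oc1ccc(F)cc1)C1OCC(C/C=C\CCC(=O)O)C(c2cccnc2)O1` — 120 nM

Compound 1 stands at the highest of the two numbers in this assay. Compound 2 gives the lower number, and the gap between compound 1 and compound 2 lies beyond the scatter; no single-point comparison links the two, so only the two values themselves are known. Both carry the same core with the pyridin-3-yl group and the 5-carboxypent-2-en-1-yl group, and differ in what sits on the saturated ring carbon between the two ring oxygen atoms.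

Compound 3 `CC(C)(Cc1ccccc1)C1OCC(C/C=C\CCC(=O)O)C(c2cccnc2)O1` is not yet measured. It differs from compound 1 as follows: 1-benzyl-1-methylethyl in place of thiophen-3-yl on a saturated ring carbon. The substituent entering compound 3 is, like that of compound 2, a branched group on the same saturated ring carbon, whereas compound 1 carries the small thiophen-3-yl there. Given that compound 2 gives 120 nM against compound 1 at 1580 nM, the step is expected to be downward and beyond the scatter: a 7.2-fold lower number from compound 1 to compound 3 (0.86 log units; beyond the scatter). For compound 3 the estimate in this assay is 220 nM, with a range from 60 nM to 800 nM.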

Compound 3, dissociation constant: 513 nM
Beside the measured number, compound 3's estimate is 2.3-fold (0.37 log units) below it; measured number inside the range.
By their numbers in this assay, from the lowest: compound 2; then compound 3; then compound 1.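

In this assay, among these compounds, 1-benzyl-1-methylethyl in place of thiophen-3-yl on the saturated ring carbon between two ring oxygen atoms gives a 3.1-fold lower number from compound 1 to compound 3 (0.49 log units; beyond the scatter) and so links this position to a measured change for the first time. Benzyl in place of 4-fluorophenoxy on the saturated chain carbon gives a 4.3-fold higher number from compound 2 to compound 3 (0.63 log units; beyond the scatter) in the same assay, which shows that the number at this position depends on the group carried by that branched carbon as well as on the branched carbon itself. Nothing at hand bears on why either step has the size it has.

Which part of 4-fluorophenoxy matters stays open, as the chain oxygen and the fluorine both go in the step to compound 3, and an unsubstituted phenoxy or a 4-fluorobenzyl group would separate the two. All the compounds shown also keep the carboxylic acid of the 5-carboxypent-2-en-1-yl group and the pyridin-3-yl group, so what an amide in place of that acid would do to the number is unknown.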